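Working notes: iodo to trifluoromethyl, compound 2 to compound 3

This account rests on a few compounds, and the source may have more. Where it says the series, first, only, none or still open, it means among the compounds named here.

Measured so far:
compound 1 `COC(=O)C1=C(C)N=C(C)/C(=C(\O)OC)C1c1ccccc1C#N` — 15.9 nM
compound 2 `COC(=O)C1=C(C)N=C(C)/C(=C(\O)OC)C1c1cccc(I)c1` — 41.7 nM

Both numbers come from a functional assay (muscle tissue) with Cavia porcellus as the target; on this read-out lower numbers stand for an effect already at smaller amounts and higher numbers for an effect only at larger amounts of compound. Compound 2 has the highest of the two numbers; its nearest neighbour is compound 1. For the measured compounds named here, the single measured step runs a 2.6-fold higher number from compound 1 to compound 2 (0.42 log units; beyond the scatter), a modest change brought by 3-iodophenyl in place of 2-cyanophenyl on a saturated ring carbon.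

Compound 3 `COC(=O)C1=C(C)N=C(C)/C(=C(\O)OC)C1c1cccc(C(F)(F)F)c1` differs from compound 2 only by trifluoromethyl in place of iodo on an aromatic carbon. Going by the values given here, no measured step exchanges one group for another at the same place on the aromatic ring, so the measured step bears on this change only loosely: it shows that an exchange of the whole aryl group moved the number by a modest amount, and a smaller exchange within one ring position is expected to do no more. The expected step in this assay is a 1.4-fold lower number from compound 2 to compound 3 (0.14 log units; within the scatter), not beyond the scatter. Compound 3 is therefore estimated at 30 nM, with a range from 10 nM to 120 nM.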

Compound 3, half-maximal effective concentration: 74.1 nM
Estimate against measurement, compound 3: 2.5-fold (0.39 log units) below; measured number inside the range.
By their numbers in this assay, from the lowest: compound 1; then compounds 2 and 3 (each within the scatter of the next).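

In this assay, for the compounds shown here, the exchange at this place on the aromatic ring gives a 1.8-fold higher number from compound 2 to compound 3 (0.25 log units; within the scatter), the first step that stays at one ring position. Iodo, with 1 heavy atom, and trifluoromethyl, with 4 heavy atoms, therefore cannot be told apart at this place on this read-out, although neither group has a hydrogen-bond donor or acceptor, so the pair does not test those features. Nothing at hand bears on the reason for this result.

From the compounds shown here alone, it remains open whether an amine or a carboxylic acid at this place would stay within the scatter of compound 2 and compound 3. Going by these compounds, it is also open whether the exchange of iodo for trifluoromethyl would give a step of similar size with the group on another carbon of the aromatic ring.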